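Chloro for bromo on the shared core: expected read-out

This account rests on a few compounds, and the source may have more. Where it says the series, first, only, none or still open, it means among the compounds named here.

Compound 3 `O=C(Nc1nn[nH]n1)c1cc(Br)ccn1` gives 34% in a functional assay on the whole organism for inhibition, with Rattus norvegicus as the target, at a dose of 3 mg/kg by the oral route; a higher number here means a stronger effect of the compound at the dose given, a lower number a weaker effect; compound 1 `CC(C)c1ccnc(C(=O)Nc2nn[nH]n2)c1` gives 34% and compound 2 `COc1cccc(C(=O)Nc2nn[nH]n2)n1` gives 36%. Compound 3 thus stands level with compound 1, the two of them the lowest numbers, and compound 2 lies within the scatter of both. Among the measured compounds shown here, the one measured step on this aromatic carbon, no change at the digits printed from compound 1 to compound 3 (within the scatter), was bromo in place of isopropyl. Compound 4 `O=C(Nc1nn[nH]n1)c1cc(Cl)ccn1` differs from compound 3 by chloro in place of bromo on an aromatic carbon. For the measured compounds named here, no measured pair swaps one halogen for another, and the only change on this aromatic carbon left the read-out unchanged, so no step beyond the scatter is expected here: no change at the digits printed from compound 3 to compound 4 (within the scatter). Compound 4 is therefore estimated at 34%, in the range 22% to 46%.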

Compound 4, a percentage reported as inhibition, in the whole organism at one dose (the size of the read-out at that dose, not a potency): 72%
Beside the measured number, compound 4's estimate is 38 percentage points below it; measured number above the stated range.
By their numbers in this assay, from the lowest: compounds 1, 3 and 2 (each within the scatter of the next); then compound 4.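

In this assay, this aromatic carbon opposite the ring nitrogen proves sensitive to its substituent: chloro in place of bromo gives a number 38 percentage points higher from compound 3 to compound 4 (beyond the scatter), and chloro in place of isopropyl gives a number 38 percentage points higher from compound 1 to compound 4 (beyond the scatter). Bromo and isopropyl had read alike here, so the earlier compounds gave no sign that exchanging one halogen for another could produce a large step. Nothing at hand accounts for this step.

As far as these compounds go, whether fluoro, methyl or an amine on this carbon would match chloro remains open. Also open, from the compounds shown here alone, is whether the step holds at other oral doses.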